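The source may report more compounds than this note shows. Statements on the series, on what has been measured and on what is new or still open speak of the compounds shown alone.

Of the compounds shown here, three built on one shared core have been tested in a functional assay on HT-29 cells (Homo sapiens) for cytotoxicity, read by MTT assay, with a stated time of 72 h; on this read-out lower numbers stand for stronger inhibition and higher numbers for weaker inhibition. Compound 1 `COc1ccc(/C=C/C(=O)Nc2cc(C(=O)c3cc(OC)c(OC)c(OC)c3)ccc2OC)cc1` gives 5010 nM. Compound 2 `COc1ccc(C(=O)c2cc(OC)c(OC)c(OC)c2)cc1NC(=O)/C=C/c1ccc(C(F)(F)F)cc1` gives 1600 nM. Compound 3 `COc1ccc(C(=O)c2cc(OC)c(OC)c(OC)c2)cc1NC(=O)/C=C/c1cccc(OC(F)(F)F)c1` gives 5200 nM. Among these three numbers compound 3 stands highest, but the gap to compound 1 is small, a 1.0-fold higher number from compound 1 to compound 3 (0.02 log units; within the scatter), whereas the gap to compound 2 is larger, a 3.3-fold higher number from compound 2 to compound 3 (0.51 log units; beyond the scatter).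

Compound 4 `COc1ccc(C(=O)c2cc(OC)c(OC)c(OC)c2)cc1NC(=O)/C=C/c1ccc(F)c(F)c1` has not yet been measured. It differs from compound 3 in one place: 3,4-difluorophenyl in place of 3-(trifluoromethoxy)phenyl on a double-bonded chain carbon bound to a double-bonded chain carbon. Two of the measured steps touch the same ring and therefore bear on this change. One swapped a single group on that ring, a 3.1-fold lower number from compound 1 to compound 2 (0.50 log units; beyond the scatter); the other exchanged the whole ring, a 3.3-fold higher number from compound 2 to compound 3 (0.51 log units; beyond the scatter). Within the data shown here, both moved the number by a modest amount, and none of the measured compounds carries two fluorines set directly on this ring, so the direction for compound 4 cannot be read off with confidence. A step of modest size or none beyond the scatter is expected in this assay, and the expected step from compound 3 to compound 4 is a 1.7-fold lower number from compound 3 to compound 4 (0.24 log units; within the scatter). For compound 4 the estimate in this assay is 3000 nM, with a range from 1200 nM to 8000 nM.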

Compound 4, half-maximal inhibitory concentration: 4200 nM
For compound 4 the middle estimate is 1.4-fold (0.15 log units) below the measured one; measured number inside the range.
By their numbers in this assay, from the lowest: compound 2; then compounds 4, 1 and 3 (each within the scatter of the next).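

In this assay, bringing in 3,4-difluorophenyl gives a 1.2-fold lower number from compound 3 to compound 4 (0.09 log units; within the scatter) and also a 1.2-fold lower number from compound 1 to compound 4 (0.08 log units; within the scatter), so three quite different rings on this double-bonded chain carbon, 4-methoxyphenyl, 3-(trifluoromethoxy)phenyl and 3,4-difluorophenyl, now read alike within the scatter. The 4-(trifluoromethyl)phenyl ring remains the one that stands apart, with a 2.6-fold higher number from compound 2 to compound 4 (0.42 log units; beyond the scatter), which shows that fluorine on this ring, whether in a trifluoromethoxy group or as two fluorines set directly on it, does not by itself bring the lower number of compound 2. There is no evidence here on why this one ring differs from the other three.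

Going by these compounds, it remains open whether the lower number of compound 2 belongs to the trifluoromethyl group itself or to where it sits, as a 3-(trifluoromethyl)phenyl ring would show. On these data alone, how rings carrying a nitrile, an amine or a carboxylic acid would read in this assay also remains open, as does whether any ring at this position can go much lower than compound 2 does.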